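This account rests on a few compounds, and the source may have more. Where it says the series, first, only, none or still open, it means among the compounds named here.

Measured in an ADME assay on microsomes from liver (Homo sapiens) for metabolic stability; on this read-out lower numbers stand for slow clearance and higher numbers for fast clearance:
Compound 1 `CCOc1cc([C@](O)(CCN(C)C)[C@@H](c2cc3cc(Br)ccc3nc2OC)c2ccnc(OC)c2OC)cc(OC)n1` gives 3.8 uL/min.
Compound 2 `COc1cc([C@](O)(CCN(C)C)[C@@H](c2cc3cc(C#N)ccc3nc2OC)c2cccc(C)c2F)cc(OC(F)F)n1` gives 0.6 uL/min.
Compound 3 `COc1cc([C@](O)(CCN(C)C)[C@@H](c2cc3cc(Br)ccc3nc2OC)c2ccnc(OC)c2OC)cc(OC(F)F)n1` gives 2.1 uL/min.

Compound 3 holds the second highest of the three numbers in this assay. Compound 1 stands nearest, and the gap between the two is within the scatter; compound 2 stands furthest, with a lower number that lies beyond the scatter. Going by the values given here, the only single-point step among the measured compounds, a 1.8-fold lower number from compound 1 to compound 3 (0.26 log units; within the scatter), concerns difluoromethyl in place of ethyl on an oxygen on an aromatic ring and has no bearing on the change now considered.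

Compound 4 `COc1cc([C@](O)(CCN(C)C)[C@@H](c2cc3cc(C#N)ccc3nc2OC)c2ccnc(OC)c2OC)cc(OC(F)F)n1` differs from compound 3 in one place: cyano in place of bromo on an aromatic carbon. Among the compounds with values here, no measured step in this assay covers cyano in place of bromo on its own. Compound 2 carries the cyano and shows a lower number than compound 3, a gap beyond the scatter, but compound 2 also differs from compound 3 elsewhere, so its value is only a loose pointer. The step is therefore expected to be modest and, if anything, toward a lower number, so a 1.6-fold lower number from compound 3 to compound 4 (0.21 log units; within the scatter) is the estimate. Compound 4 is estimated at 1.3 uL/min in this assay, with a range from 0.5 uL/min to 3.5 uL/min.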

Compound 4, intrinsic clearance in a liver preparation (reported as CLH), per the amount of preparation that the assay uses: 2.5 uL/min
Compound 4: middle estimate off by 1.9-fold (0.28 log units), on the low side, within the range that was stated.
By their numbers in this assay, from the lowest: compound 2; then compounds 3, 4 and 1 (each within the scatter of the next).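

Cyano in place of bromo on this aromatic carbon gives, in this assay, a 1.2-fold higher number from compound 3 to compound 4 (0.08 log units; within the scatter), so with 2,3-dimethoxypyridin-4-yl on the saturated chain carbon this read-out does not separate the two groups. With cyano common to both compounds, 2,3-dimethoxypyridin-4-yl in place of 2-fluoro-3-methylphenyl gives a 4.2-fold higher number from compound 2 to compound 4 (0.62 log units; beyond the scatter), so the low number of compound 2 cannot be read as a feature of the cyano group alone and tracks the 2-fluoro-3-methylphenyl group within this pair. Nothing at hand explains either step.

Whether cyano and bromo also stay within the scatter of each other alongside 2-fluoro-3-methylphenyl remains open, since the compounds shown give that swap only alongside 2,3-dimethoxypyridin-4-yl. Also open, from the compounds shown here alone, is how far this aromatic carbon tolerates change in this assay beyond these two groups, for example with a chloro, a trifluoromethyl, a carboxylic acid or an amine in the same place.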